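The compounds below may be only part of what the source reports. "The series", "measured", "known", "first", "only" and "open" are said of these compounds alone.

Compound 3 `COc1cccc(CNCCCNc2ccnc3cc(-c4cccc5ccccc45)ccc23)c1O` stands level with compound 2 `COc1cccc(CNCCCNc2ccnc3cc(-c4ccc(C(F)(F)F)cc4)ccc23)c1O` in a physicochemical assay for solubility, with a stated time of 18 h, at pH 7.4 (a lower number here means a less soluble compound, a higher number a more soluble compound), to the digits given: compound 3 gives 32000 nM and compound 2 gives 32000 nM, together the highest of the three numbers. Compound 1 `COc1cccc(CNCCCNc2ccnc3cc(Oc4ccc(Cl)cc4)ccc23)c1O` gives 14500 nM and is the furthest from compound 3; that gap is a 2.2-fold higher number from compound 1 to compound 3 (0.34 log units; beyond the scatter). Compound 4 `COc1cccc(CNCCCNc2ccnc3cc(CC4CCCCC4)ccc23)c1O` differs from compound 3 by cyclohexylmethyl in place of naphthalen-1-yl on an aromatic carbon. Within the data shown here, no measured step exchanges an aromatic group for a non-aromatic ring at this position; the nearest comparisons are no change at the digits printed from compound 2 to compound 3 (within the scatter) and a 2.2-fold higher number from compound 1 to compound 2 (0.34 log units; beyond the scatter), one within the scatter and one modest. The shared core is unchanged throughout. The step of a 1.1-fold lower number from compound 3 to compound 4 (0.03 log units; within the scatter) is therefore expected, not clearly beyond the scatter in either direction. Compound 4 is estimated at 30000 nM, with a range from 12000 nM to 75000 nM.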

Compound 4, solubility: 4200 nM
Beside the measured number, compound 4's estimate is 7.1-fold (0.85 log units) above it; the measured number lies below the stated range.
By their numbers in this assay, from the lowest: compound 4; then compound 1; then compounds 2 and 3 (each within the scatter of the next).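

In this assay, among these compounds, cyclohexylmethyl is the only group at this position without an aromatic ring, and compound 4 falls below all three compounds that carry one (a 7.6-fold lower number from compound 3 to compound 4 (0.88 log units; beyond the scatter)) (a 7.6-fold lower number from compound 2 to compound 4 (0.88 log units; beyond the scatter)) (a 3.5-fold lower number from compound 1 to compound 4 (0.54 log units; beyond the scatter)). Among the compounds shown here, in these four compounds, therefore, the higher numbers go with an aromatic ring in this group, with no compound against that pattern, though the non-aromatic side rests on compound 4 alone. No measured evidence accounts for the fall.

As far as these compounds go, whether the ring itself or its link to the core matters remains open, since naphthalen-1-yl and cyclohexylmethyl differ in both. Benzyl, set against cyclohexylmethyl, would separate the two.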